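Opening the Ring on the Carbonyl Carbon

This account rests on a few compounds, and the source may have more. Where it says the series, first, only, none or still open, it means among the compounds named here.

Of the compounds shown here, three have been measured in a functional assay on the whole organism (Tail, strain ICR) with Mus musculus as the target, in the tail flick test, with a stated time of 150 min, at a dose of 25 umol/kg by the oral route; a higher number here means a stronger effect of the compound at the dose given, a lower number a weaker effect. Compound 1, `O=C(O)[C@@H]1CCCN1C(=O)CN(c1nc(Cl)nc2[nH]cnc12)C1CC1`, gives 7.29% there. Compound 2, `CC(C)[C@H](NC(=O)CN(c1nc(Cl)nc2[nH]cnc12)C1CC1)C(=O)OCc1ccccc1`, gives 17.9%, and compound 3, `O=C(CN(c1ncnc2c1ncn2C1CCCCO1)C1CC1)NCC(=O)OCc1ccccc1`, gives 7.26%. Among these three numbers compound 1 stands second highest; its nearest neighbour is compound 3, a number within the usual scatter of it, while compound 2 lies farthest from it, a number beyond the scatter above it.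

Compound 4, `C[C@@H](O)[C@H](NC(=O)CN(c1nc(Cl)nc2[nH]cnc12)C1CC1)C(=O)O`, has not yet been measured. It differs from compound 1 in one place: (1-carboxy-2-hydroxypropyl)amino in place of 2-carboxypyrrolidin-1-yl on a carbonyl carbon. The change opens the five-membered ring and adds hydrogen-bond donors while keeping the carboxylic acid and the shared core unchanged.

Within the data shown here, no measured pair shows a step of this kind, so the account rests on the values alone. Among the measured compounds shown here, compound 4 is expected to stay close to compound 1, with a step of a number 1.7 percentage points higher from compound 1 to compound 4 (within the scatter) that lies within the scatter, since compound 1 gives 7.29% and the only higher number belongs to compound 2 with a different group. Compound 4 is therefore estimated at 9%, within a range from 2% to 20%.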

Compound 4, a percentage reported as activity, at one dose (the size of the read-out at that dose, not a potency): 24%
Beside the measured number, compound 4's estimate is 15 percentage points below it, and the stated range ends below it.
By their numbers in this assay, from the lowest: compounds 3 and 1 (each within the scatter of the next); then compounds 2 and 4 (each within the scatter of the next).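

In this assay, among these compounds, (1-carboxy-2-hydroxypropyl)amino in place of 2-carboxypyrrolidin-1-yl on a carbonyl carbon brings a number 16.7 percentage points higher from compound 1 to compound 4 (beyond the scatter) and gives the first reading of a change at this position, which no earlier pair could provide. Both groups carry a carboxylic acid and have the same number of heavy atoms, so neither of these features alone sets the read-out here. No measurement available here accounts for the step.

The compounds shown leave open whether the gain follows from opening the ring or from the added hydroxy group, since the two changes arrive together. A 2-carboxy-4-hydroxypyrrolidin-1-yl group, which keeps the ring and adds the hydroxy group, or a (1-carboxypropyl)amino group, which opens the ring without it, would separate the two.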